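Bromo for methoxy on a triazole aryl arm

The source may report more compounds than this note shows. Statements on the series, on what has been measured and on what is new or still open speak of the compounds shown alone.

For the measured compounds named here, compound 3 `C=C1C(=O)[C@]23C[C@@]1(O)CC[C@H]2c1ccc(O)c(C)c1[C@@H]3Cn1cc(-c2ccc(OC)cc2)nn1` is the one member of this set with a numerical reading: in a functional assay on SW480 cells (Homo sapiens) for cytotoxicity, read by MTT assay, with a stated time of 4 days (on this read-out higher numbers stand for weaker inhibition and lower numbers for stronger inhibition), compound 3 gives 220 nM. Compound 1 `COc1ccc(-c2cn(C[C@H]3c4c(ccc(OS(=O)(=O)c5ccc(C)cc5)c4C)[C@@H]4CC[C@@]5(C)C[C@]43CC5=O)nn2)cc1` reaches only the limit of this assay, giving > 20000 nM. Compound 2 `Cc1ccc(S(=O)(=O)Oc2ccc3c(c2C)[C@H](Cn2cc(-c4ccc(Br)cc4)nn2)[C@@]24CC(=O)[C@@](C)(CC[C@@H]32)C4)cc1` likewise stops at the limit, giving > 20000 nM. The two limits make the step that the two limits leave unreadable from compound 1 to compound 2 unreadable, and the limit of > 20000 nM in this assay, at which 2 of the 3 values shown sit, is all that can be said of that pair. The difference between the core of compound 1 and the core of compound 3 is not broken down here.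

Compound 4 `C=C1C(=O)[C@]23C[C@@]1(O)CC[C@H]2c1ccc(O)c(C)c1[C@@H]3Cn1cc(-c2ccc(Br)cc2)nn1` is built from compound 3 by the change (bromo in place of methoxy on an aromatic carbon), the same change that separates compound 1 from compound 2, (bromo in place of methoxy on an aromatic carbon). Going by the values given here, since the only measured instance of this change gives no readable size, the expectation for compound 4 rests on compound 3 alone, whose reading of 220 nM is taken as the anchor, with a step of a 1.4-fold higher number from compound 3 to compound 4 (0.13 log units; within the scatter) expected to stay modest. Compound 4 is therefore estimated to give 300 nM in this assay, between 100 nM and 900 nM.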

Compound 4, half-maximal inhibitory concentration: 310 nM
For compound 4 the middle estimate is 1.0-fold (0.01 log units) below the measured one; low and high end bracket the measured number.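

In this assay, bromo in place of methoxy on the core of compound 3 gives a 1.4-fold higher number from compound 3 to compound 4 (0.15 log units; within the scatter), so on this core the 4-methoxyphenyl and 4-bromophenyl arms cannot be told apart. For the compounds shown here, on the core of compound 1 the same change cannot be read, since both members of that pair stop at a limit and not at a number: the limit of > 20000 nM in this assay, at which 2 of the 4 values shown sit. The series therefore offers only one readable instance of the change, which shows that it is tolerated on the core of compound 3 but not that its size carries over to the core of compound 1.

The compounds shown leave open how an amine, a carboxylic acid or a longer chain such as butoxy would read in place of methoxy on that aromatic carbon of the core of compound 3. They also leave open which part of the difference between the two cores matters, as those cores differ in more than one place.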